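The compounds below may be only part of what the source reports. "The series", "measured", "known", "first", "only" and "open" are said of these compounds alone.

Compound 1 `Cc1cc(F)c2ncn(-c3ccc(C(=O)NC4CC4)s3)c2c1`: in an in vitro ADME assay on microsomes from liver (Mus musculus) for pharmacokinetics, read by LC-MS (a higher number here means faster removal of the compound, a lower number slower removal), compound 1 gives > 72 mL/min/kg, which is a limit of the assay rather than a number.
Compound 2 `Cc1nc2c(Cl)cc(F)cc2n1-c1ccc(C(=O)NC2CC2)s1`: in this assay compound 2 gives 42 mL/min/kg.
Compound 3 `O=C(NC1CC1)c1ccc(-n2cnc3c(Cl)cc(F)cc32)s1`: in this assay compound 3 gives > 72 mL/min/kg, again a limit of the assay and not a number.

Compound 2 and compound 3 differ in a single place: hydrogen in place of methyl on an aromatic carbon. That change produced an at least 1.7-fold higher number from compound 2 to compound 3 (0.23 log units; that floor lies within the scatter). Since compound 3 sits at the limit of > 72 mL/min/kg in this assay, at which 2 of the 3 values shown sit, only the floor of that step is known, not its full size. Compound 1 and compound 2 also differ, but the difference between their two cores is not broken down here.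

Compound 4 `O=C(NC1CC1)c1ccc(-n2cnc3c(F)cccc32)s1` has not yet been measured. It differs from compound 1 by hydrogen in place of methyl on an aromatic carbon. This is the same kind of change as from compound 2 to compound 3, though not the same change: in compound 2 the methyl sits on a five-membered aromatic ring with 2 nitrogen, between two ring nitrogen atoms, next to the ring atom that bears a large group, whereas in compound 1 it sits on a six-membered aromatic ring of carbon only, meta to a fluoro group, meta to a fused ring and para to a fused ring.

Compound 4 is expected to give 95 mL/min/kg in this assay. That estimate means a step that the limit leaves unreadable from compound 1 to compound 4, and it rests on compound 1 already sitting at the limit of > 72 mL/min/kg in this assay, at which 2 of the 3 values shown sit, together with the direction of an at least 1.7-fold higher number from compound 2 to compound 3 (0.23 log units; that floor lies within the scatter).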

Compound 4, clearance: > 72 mL/min/kg
Compound 4 was reported as a limit; the forecaster's own chance of this, stated with the estimate: 75%; the middle value does not contradict the limit.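

In this assay compound 1 and compound 4 both stand only as limits of the assay, not as numbers, so no step between them can be read: the limit of > 72 mL/min/kg in this assay, at which 3 of the 4 values shown sit.

The compounds shown leave open how fast compound 1 and compound 4 are really removed, and whether hydrogen in place of methyl on the six-membered aromatic ring of carbon only changes that removal at all.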